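Propylsulfonyl in Place of tert-Butyl: An Open Question

This account rests on a few compounds, and the source may have more. Where it says the series, first, only, none or still open, it means among the compounds named here.

Two compounds have been measured in a functional assay (aorta) with Oryctolagus cuniculus as the target; on this read-out higher numbers stand for weaker inhibition and lower numbers for stronger inhibition:

Compound 1: `Fc1ccccc1Cn1nc(-c2nn[nH]n2)c2cccnc21` — 8600 nM
Compound 2: `CC(C)(C)c1cnc(-c2nn(Cc3ccccc3F)c3ncccc23)nc1N` — 709000 nM

Compound 2 stands highest of the two numbers, which on this read-out means the weaker inhibition. Its nearest neighbour is compound 1, whose number lies far lower, a gap well beyond the usual scatter of this kind of measurement. For the measured compounds named here, the two share a core but differ in several places at once, so the figures show only that compound 1 inhibits far more strongly than compound 2, and nothing about which part of the structure is responsible.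

Compound 3 `CCCS(=O)(=O)c1cnc(-c2nn(Cc3ccccc3F)c3ncccc23)nc1N` has not yet been measured. It differs from compound 2 in a single place: propylsulfonyl in place of tert-butyl on an aromatic carbon. Going by the values given here, no pair of measured compounds shares this change, so there is no step to lean on, and the direction must be judged without precedent. The estimated step of a 3.5-fold lower number from compound 2 to compound 3 (0.55 log units; beyond the scatter) is a modest fall in the number, though the uncertainty is wide. Compound 3 is expected to give about 200000 nM, within a range from 30000 nM to 1500000 nM.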

Compound 3, half-maximal inhibitory concentration: 378000 nM
Beside the measured number, compound 3's estimate is 1.9-fold (0.28 log units) below it; the measured number falls inside the stated range.
By their numbers in this assay, from the lowest: compound 1; then compounds 3 and 2 (each within the scatter of the next).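

In this assay, putting propylsulfonyl in place of tert-butyl on this aromatic carbon, ortho to an amino group, amounts to a 1.9-fold lower number from compound 2 to compound 3 (0.27 log units; within the scatter), so this read-out does not separate the two compounds. The earlier compounds shown here could not show this, since they differ in several places at once; this pair shows that at this one position a branched all-carbon group and a sulfonyl-bearing chain with hydrogen-bond acceptors can be exchanged with no change beyond the scatter. Nothing measured here accounts for this outcome.

The compounds shown leave open whether any other group on this carbon, such as an amine, a carboxylic acid, a methylsulfonyl or a longer chain, would shift the number beyond the scatter, so a single exchange cannot yet describe what this position tolerates. They also leave open what the neighbouring amino group contributes, and whether replacing it with a hydrogen or a methoxy group would alter the number or change how either tert-butyl or propylsulfonyl behaves here.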